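The source may hold more compounds than are shown below. What is called first, only, known or untested is meant among the compounds shown, and "the series" means these compounds.

Working notes on the series. The shared core of compound 1 `NS(=O)(=O)c1ccc(-c2nc(C(c3ccc(F)cc3)c3ccc(F)cc3)sc2CC(=O)O)cc1` is kept in compound 2 `CS(=O)(=O)Nc1cccc(-c2nc(C(c3ccc(F)cc3)c3ccc(F)cc3)sc2CC(=O)O)c1` and compound 3 `N#Cc1ccc(-c2nc(C(c3ccc(F)cc3)c3ccc(F)cc3)sc2CC(=O)O)cc1`, which differ only in the aryl group on the core. In an in vitro functional assay on HEK285-7 cells for antagonist activity at prostaglandin D2 receptor 2 (Homo sapiens), read by BRET and beta-arrestin recruitment (a lower number here means a smaller maximal response, a higher number a larger maximal response), compound 1 gives 80%, compound 2 gives 80% and compound 3 gives 30%. The change no change at the digits printed from compound 1 to compound 2 (within the scatter) leaves the read-out where it was, whereas a number 50 percentage points lower from compound 1 to compound 3 (beyond the scatter) and a number 50 percentage points lower from compound 2 to compound 3 (beyond the scatter) are both large drops. Compound 3 therefore stands lowest of the three numbers in this assay, with compound 1 and compound 2 each above it by a margin beyond the scatter.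

Compound 4 `O=C(O)Cc1sc(C(c2ccc(F)cc2)c2ccc(F)cc2)nc1-c1ccnc(Cl)c1` is the next step from compound 3: 2-chloropyridin-4-yl in place of 4-cyanophenyl on an aromatic carbon. Among the compounds with values here, no measured step covers this particular exchange. Within the data shown here, what bears on it is only that the two steps onto the 4-cyanophenyl group, a number 50 percentage points lower from compound 1 to compound 3 (beyond the scatter) and a number 50 percentage points lower from compound 2 to compound 3 (beyond the scatter), were large, so the aryl group on this carbon can move the maximal response by a wide margin in either direction. From compound 3 an upward step is expected, a number 20 percentage points higher from compound 3 to compound 4 (beyond the scatter), but the direction is uncertain because compound 3 gives 30% while compound 1 and compound 2 with their sulfonamide-bearing rings sit higher by a margin beyond the scatter. The estimate for compound 4 in this assay is 50%, within 20% to 85%.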

Compound 4, largest response reached (reported as efficacy), in percent of the reference or control that the assay uses: 80%
Estimate against measurement, compound 4: 30 percentage points below; low and high end bracket the measured number.
By their numbers in this assay, from the lowest: compound 3; then compounds 1, 2 and 4 (each within the scatter of the next).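

In this assay, 2-chloropyridin-4-yl in place of 4-cyanophenyl on this aromatic carbon gives a number 50 percentage points higher from compound 3 to compound 4 (beyond the scatter), so the low maximal response of compound 3 is not shared by every small aryl group at this position. The ring of compound 4 has neither a sulfamoyl nor a methanesulfonamido group, yet there is no change at the digits printed from compound 1 to compound 4 (within the scatter) and no change at the digits printed from compound 2 to compound 4 (within the scatter), which shows that a sulfur-bearing substituent is not required for this level of response among the compounds shown; three different aryl groups now sit together, and compound 3 alone goes against them. Nothing available gives a reason for this result.

Still open, going by these compounds, is whether the low number of compound 3 belongs to the nitrile itself or to the 4-cyanophenyl group as a whole, and whether the chlorine or the ring nitrogen of 2-chloropyridin-4-yl matters. An unsubstituted phenyl, a pyridin-4-yl without chlorine, or a phenyl ring carrying an amine or a carboxylic acid on this carbon would help separate these possibilities.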